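Working notes: methylamino to benzylamino

The source may report more compounds than this note shows. Statements on the series, on what has been measured and on what is new or still open speak of the compounds shown alone.

Compound 1 `O=C(NCc1ccc(F)cc1)c1nc(Br)c2cccnc2c1NCc1ccc(F)cc1` gives > 20000 nM (a limit)
Compound 2 `C[C@H](Nc1c(C(=O)NCc2ccc(F)cc2)nc(Br)c2cccnc12)c1ccccc1` gives > 20000 nM (a limit)
Compound 3 `CNc1c(C(=O)NCc2ccc(F)cc2)nc(Br)c2cccnc12` gives > 20000 nM (a limit)

All readings come from a functional assay on HCT-116 cells (Homo sapiens) for cytotoxicity, read by MTT assay, with a stated time of 72 h (on this read-out higher numbers stand for weaker inhibition and lower numbers for stronger inhibition), and share one picture: the limit of > 20000 nM in this assay, at which 3 of the 3 values shown sit (no number yet for any compound). Compound 3 stands only at its limit of > 20000 nM in this read-out.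

The change to compound 4 `O=C(NCc1ccc(F)cc1)c1nc(Br)c2cccnc2c1NCc1ccccc1` is phenyl in place of hydrogen on a saturated chain carbon bound to a nitrogen on an aromatic ring in the difference between the two structures, so methylamino becomes benzylamino. The nearest measured change is a step that the two limits leave unreadable from compound 1 to compound 3 on that same saturated chain carbon. The other two changes on that nitrogen are a step that the two limits leave unreadable from compound 1 to compound 2 and a step that the two limits leave unreadable from compound 2 to compound 3 in the same series. For the measured compounds named here, none of the three gives a readable size, so no measured step points to a gain or a loss. The estimated step is a step that the limit leaves unreadable from compound 3 to compound 4 and nothing beyond the scatter is expected in this assay for it. Compound 4 is expected at about 25000 nM with an estimated range of 10000 nM to 50000 nM and most likely only a limit will be reported.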

Compound 4, half-maximal inhibitory concentration: > 20000 nM
Compound 4: no number, only a limit; the forecaster's own chance of this, stated with the estimate: 85%; the middle value is on the limit's open side.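

Compound 4 sits at a limit, like compound 1, compound 2 and compound 3, so none of its steps to those compounds can be read: the limit of > 20000 nM in this assay, at which 4 of the 4 values shown sit.

The compounds shown leave open whether any change on that nitrogen shifts the result in this assay, as none of them yet carries a number.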